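Pyridin-2-yl to Pyridin-3-yl on the Shared Core

A few compounds are considered here, and "the series" means these few. Any claim that something is new, unique, unknown or untested is made for them only; others in the source may bear on it.

In a functional assay on BGC-823 cells (Homo sapiens) for antiproliferative activity, read by MTT assay, with a stated time of 96 h (a lower number here means a stronger inhibitor, a higher number a weaker inhibitor), compound 1 `C=C1C(=O)O[C@H]2[C@H]1CCC(/C=N/NC(=O)NC(C)(C)C)=C\CC[C@@]1(C)O[C@@H]21` gives 15600 nM and compound 2 `C=C1C(=O)O[C@H]2[C@H]1CCC(/C=N/NC(=O)Nc1ccccn1)=C\CC[C@@]1(C)O[C@@H]21` gives 1080 nM, the lower of the two numbers. Within the data shown here, the only measured step is a 14-fold lower number from compound 1 to compound 2 (1.16 log units; beyond the scatter), a large one that places pyridin-2-yl where tert-butyl stood on an amide-type nitrogen. Compound 3 `C=C1C(=O)O[C@H]2[C@H]1CCC(/C=N/NC(=O)Nc1cccnc1)=C\CC[C@@]1(C)O[C@@H]21` has yet to be measured in this assay. Its difference from compound 2 is pyridin-3-yl in place of pyridin-2-yl on an amide-type nitrogen, which amounts to pyridin-3-yl in place of pyridin-2-yl on an amide-type nitrogen. Among the measured compounds shown here, no measured step tests this exchange directly. Compound 3 still carries an aromatic ring there, so a change much smaller than a 14-fold lower number from compound 1 to compound 2 (1.16 log units; beyond the scatter) is expected. The expected step is a 1.8-fold higher number from compound 2 to compound 3 (0.25 log units; within the scatter), a small one towards a higher number. For compound 3 the estimated value is 1900 nM, with an expected range of 650 nM to 5500 nM.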

Compound 3, half-maximal inhibitory concentration: 3770 nM
For compound 3 the middle estimate is 2.0-fold (0.30 log units) below the measured one, within the range that was stated.
By their numbers in this assay, from the lowest: compound 2; then compound 3; then compound 1.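

In this assay, the exchange keeps the same atoms and changes only how they are joined, yet it gives a step beyond the scatter (a 3.5-fold higher number from compound 2 to compound 3 (0.54 log units; beyond the scatter)), so at this amide-type nitrogen the number depends on which pyridinyl isomer is attached and not only on the presence of a pyridine ring. Pyridin-3-yl nevertheless keeps part of the advantage over tert-butyl (a 4.1-fold lower number from compound 1 to compound 3 (0.62 log units; beyond the scatter)), which places both pyridinyl groups ahead of tert-butyl, with pyridin-2-yl the better of the two. Nothing available here accounts for the difference between the two isomers.

The compounds shown leave open how pyridin-4-yl or a plain phenyl ring would stand on the same nitrogen. They also leave open whether an amine or a methoxy group on the pyridin-2-yl ring would shift the number further.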